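This account rests on a few compounds, and the source may have more. Where it says the series, first, only, none or still open, it means among the compounds named here.

Of the compounds shown here, two have so far been measured in a functional assay with muscarinic acetylcholine receptor M3 (Cavia porcellus) as the target; a lower number here means a smaller maximal response, a higher number a larger maximal response. Compound 1 `C[C@@H]1O[C@@H](C[N+](C)(C)C)C[C@H]1F` gives 0.74, and compound 2 `C[C@@H]1O[C@H](C[N+](C)(C)C)C[C@@H]1F` gives 0.76. These two share every atom and bond and differ only in configuration as drawn (the fact that compounds 1 and 2 differ only in the configuration as drawn), and the resulting step is a number 0.020 higher from compound 1 to compound 2 (within the scatter), so compound 2 stands alongside compound 1 within the usual scatter rather than apart from it.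

Compound 3 `C[C@@H]1O[C@@H](C[N+](C)(C)C)C[C@@H]1F` is the next step from compound 2: the two compounds have the same atoms and bonds and differ only in configuration as drawn: 1 of 3 stereo elements differ; a stereocentre at a saturated ring carbon is drawn S in compound 2 and R in compound 3. Among the measured compounds shown here, the only measured step that bears on this is the inversion of two stereocentres, which gave a number 0.020 higher from compound 1 to compound 2 (within the scatter), that is, no movement beyond the scatter. A single inversion at one saturated ring carbon is therefore expected to leave the maximal response essentially where compound 2 has it. Compound 3 is estimated at 0.75, with a range from 0.6 to 0.9. This amounts to an expected step of a number 0.010 lower from compound 2 to compound 3 (within the scatter).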

Compound 3, intrinsic activity: the largest response reached, as a fraction of the reference agonist's: 0.52
For compound 3 the middle estimate is 0.23 above the measured one; the measured number lies below the stated range.
By their numbers in this assay, from the lowest: compound 3; then compounds 1 and 2 (each within the scatter of the next).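

In this assay, a single stereocentre at a saturated ring carbon turns out to matter, giving a number 0.24 lower from compound 2 to compound 3 (beyond the scatter) and also a number 0.22 lower from compound 1 to compound 3 (beyond the scatter). The earlier pair could not show this, as two stereocentres differed there and the net result was a number 0.020 higher from compound 1 to compound 2 (within the scatter); the effect of one inversion therefore depends on the configuration at the rest of the core, and two inversions need not add up to the sum of their single effects. The maximal response of compound 3 can be traced to its spatial arrangement alone: the fact that compounds 2 and 3 differ only in the configuration as drawn

The compounds shown leave open whether this sensitivity to configuration is specific to the fluoro group. A hydroxyl group in its place, or an ethyl group in place of the methyl, might respond to the same inversions quite differently.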